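Notes on replacing chloro with hydroxy

The compounds below may be only part of what the source reports. "The series", "measured", "known", "first", "only" and "open" are said of these compounds alone.

In a functional assay on L1210 cells (Mus musculus) for inhibition (on this read-out higher numbers stand for weaker inhibition and lower numbers for stronger inhibition), compound 3 (`Nc1ccn(C/C=C/CCl)c(=O)n1`) gives 50000 nM. Compound 2 (`Nc1ncnc2c1ncn2C/C=C/CCl`) gives 45000 nM, within the scatter of compound 3. Compound 1 (`Nc1nc(O)c2ncn(C/C=C/CO)c2n1`) gives 200000 nM, beyond the scatter from both, so compound 3 stands with compound 2 on the stronger-inhibition side of this small set.

Compound 4 (`Nc1ccn(C/C=C/CO)c(=O)n1`) is not yet measured and differs from compound 3 as follows: hydroxy in place of chloro on a saturated chain carbon bound to a double-bonded chain carbon. That is hydroxy in place of chloro on a saturated chain carbon bound to a double-bonded chain carbon. Among the compounds with values here, no measured pair isolates this change, and compound 1 and compound 2 differ in more than one place. Within the data shown here, the only hint is compound 1, the one measured compound with hydroxy on that chain, at 200000 nM. A moderate step beyond the scatter, toward weaker inhibition, is therefore expected. The expected change is a 3.0-fold higher number from compound 3 to compound 4 (0.48 log units; beyond the scatter). In this assay the estimated value for compound 4 is 150000 nM, with an expected range of 60000 nM to 400000 nM.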

Compound 4, half-maximal inhibitory concentration: > 550000 nM
Compound 4 gave a limit, no number; the forecaster's own chance of this, stated with the estimate: 15%; middle value at least 3.6-fold (0.56 log units) from the limit.
By their numbers in this assay, from the lowest: compounds 2 and 3 (each within the scatter of the next); then compound 1. At a limit, above all of these: compound 4.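

In this assay, within the data shown here, the only pair differing in one place shows that this position is sensitive: hydroxy in place of chloro on a saturated chain carbon bound to a double-bonded chain carbon gives an at least 11-fold higher number from compound 3 to compound 4 (1.04 log units; beyond the scatter). Compound 4 stands as a limit and not a number, so the step has a lower bound but no upper one: the limit of > 550000 nM in this assay, at which 1 of the 4 values shown sits. On the core of compound 3, chloro therefore gives a readable inhibition on this chain and hydroxy does not, a finding that holds for this core alone.

From the compounds shown here alone, whether bromo, methoxy or an amine on the same carbon would stay near compound 3 remains open. Also open, going by these compounds, is whether the same change on the core of compound 2 would give a step of similar size.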